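The compounds below may be only part of what the source reports. "The series", "measured", "known", "first", "only" and "open" are said of these compounds alone.

Compound 2 `COc1ccc(-c2nc3cc(F)ccc3s2)cc1` carries a methyl on an oxygen on an aromatic ring; in a functional assay on MCF7 cells (Homo sapiens) for inhibition (a higher number here means a weaker inhibitor, a lower number a stronger inhibitor), compound 2 gives 490 nM. Compound 1 `Oc1ccc(-c2nc3cc(F)ccc3s2)cc1` differs from it in one place: hydrogen in place of methyl on an oxygen on an aromatic ring. That change produced a 1.2-fold lower number from compound 2 to compound 1 (0.09 log units; within the scatter), so in this assay compound 1 gives 400 nM. Compound 3 `COc1cc(-c2nc3cc(F)ccc3s2)cc(OC)c1OC` is built on a different core, and how its core differs from that of compound 2 is not broken down here. In this assay compound 3 gives 1.9 nM, the lowest of the three numbers, and its steps to both compound 1 and compound 2 lie beyond the scatter. Compound 4 `COc1cc(-c2nc3cc(F)ccc3s2)cc(O)c1OC` has not yet been measured. It differs from compound 3 by hydrogen in place of methyl on an oxygen on an aromatic ring, the same change that turned compound 2 into compound 1, made at a place described in the same words. The step of a 1.3-fold higher number from compound 3 to compound 4 (0.12 log units; within the scatter) is expected to be small because a 1.2-fold lower number from compound 2 to compound 1 (0.09 log units; within the scatter) stayed within the scatter when this change was made once before. On that basis compound 4 is expected to give about 2.5 nM in this assay, most likely between 0.8 nM and 8 nM.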

Compound 4, half-maximal inhibitory concentration: 653 nM
Compound 4: middle estimate off by 260-fold (2.42 log units), on the low side, and the stated range ends below it.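

The change from methoxy to hydroxy did not behave alike on the two cores in this assay: the same change on two cores in this assay, a 1.2-fold lower number (0.09 log units; within the scatter) from compound 2 to compound 1 and a 340-fold higher number (2.54 log units; beyond the scatter) from compound 3 to compound 4, 420-fold (2.62 log units) apart, beyond the scatter of two such steps

On the core of compound 3 the change matters a great deal, with a 340-fold higher number from compound 3 to compound 4 (2.54 log units; beyond the scatter), so the small step seen on the core of compound 2 proved no reliable guide to its size on another core in this series. Among these compounds, with only two pairs available, this does not show which feature of the cores separates the two results, nor how the same change would behave on a third core.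

The compounds shown leave open whether the other methoxy groups of compound 3 are just as sensitive to becoming hydroxy. They also leave open whether a different group at the place changed in compound 4, such as an amine or a longer chain like ethoxy, would stay close to compound 3 or fall closer to compound 4.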